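Side-chain changes at the ring amine: compound 4

A few compounds are considered here, and "the series" means these few. Any claim that something is new, unique, unknown or untested is made for them only; others in the source may bear on it.

Compound 1, `CS(=O)(=O)Oc1c(C(=O)NCc2ccc(F)cc2)nc(Br)c2cccnc12`: in a functional assay on HCT-116 cells (Homo sapiens) for cytotoxicity, read by MTT assay, with a stated time of 72 h (a lower number here means a stronger inhibitor, a higher number a weaker inhibitor), compound 1 gives > 20000 nM, which is a limit of the assay and not a number.
Compound 2, `CNCCCNc1c(C(=O)NCc2ccc(F)cc2)nc(Br)c2cccnc12`: in this assay compound 2 gives 9000 nM.
Compound 3, `O=C(NCCCNc1c(C(=O)NCc2ccc(F)cc2)nc(Br)c2cccnc12)c1ccccc1`: in this assay compound 3 gives > 10000 nM, again a limit of the assay and not a number.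

Compound 3 therefore stands only at a limit; it cannot be placed against compound 2 beyond what that limit allows. Two steps are measured. Putting (3-(methylamino)propyl)amino in place of (methylsulfonyl)oxy on an aromatic carbon gave an at least 2.2-fold lower number from compound 1 to compound 2 (0.34 log units; beyond the scatter), the starting point being (the limit of > 20000 nM in this assay, at which 1 of the 3 values shown sits). Putting benzoyl in place of methyl on the amine nitrogen gave an at least 1.1-fold higher number from compound 2 to compound 3 (0.04 log units; that floor lies within the scatter), with the floor set by the limit of > 10000 nM in this assay, at which 1 of the 3 values shown sits.

Compound 4, `O=C(NCc1ccc(F)cc1)c1nc(Br)c2cccnc2c1NCc1ccc(F)cc1`, differs from compound 3 by 4-fluorophenyl in place of 2-benzamidoethyl on a saturated chain carbon bound to a nitrogen on an aromatic ring. Neither measured step exchanges a chain for an aromatic ring at this position, so neither bears on it directly; the nearest, the step from compound 2 to compound 3, stayed within the scatter while the chain was lengthened with a benzoyl group. No step beyond the scatter is therefore expected in this assay, in either direction. The expected step is a number no higher from compound 3 to compound 4 (the limit leaves the size open). Compound 4 is estimated at 10000 nM, with a range from 2500 nM to 40000 nM.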

Compound 4, half-maximal inhibitory concentration: > 20000 nM
Compound 4 ended at the assay's limit (the forecaster's own chance of this, stated with the estimate: 50%); middle value at least 2.0-fold (0.30 log units) away from the limit.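

In this assay compound 4 gives > 20000 nM, which is a limit of the assay and not a number. Putting 4-fluorophenyl in place of 2-(methylamino)ethyl on a saturated chain carbon bound to a nitrogen on an aromatic ring gave an at least 2.2-fold higher number from compound 2 to compound 4 (0.34 log units; beyond the scatter), so this position responds to the change, whereas the earlier change further out on the chain, benzoyl in place of methyl on the amine nitrogen, gave only a floor within the scatter. Among the compounds shown here, the steps to compound 4 from compound 1 and from compound 3 cannot be read, and compound 2 remains the only one of the four compounds with a measured number rather than a limit.

From the compounds shown here alone, what remains open is whether the number for compound 2 depends on the terminal methylamino group or on the chain that carries it, which a primary amine, a dimethylamino group or a longer chain could separate. Going by these compounds, it is also open whether a carboxylic acid at the chain end would stay at a limit, as the benzamide of compound 3 does.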